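Chain Extension at the Piperazine Amide and Cytotoxicity

The compounds below may be only part of what the source reports. "The series", "measured", "known", "first", "only" and "open" are said of these compounds alone.

Measured compounds:
compound 1 `CN1CCN(CC(=O)N2CCC3(N4CCCC4)CC(c4ccccc4)C2C(c2ccccc2)C3)CC1`: 69100 nM
compound 2 `CN1CCN(CC(=O)N2CCC3(N(C)C)CC(c4ccccc4)C2C(c2ccccc2)C3)CC1`: 195000 nM

Of the compounds shown here, two have been measured in an ADME assay on L6 cells (Rattus norvegicus) for cytotoxicity, read by resazurin assay, with a stated time of 72 h; on this read-out higher numbers stand for weaker inhibition and lower numbers for stronger inhibition. In this assay compound 1 gives 69100 nM, the lowest of the two numbers. Among the measured compounds shown here, compound 2 gives 195000 nM, the only measured step being a 2.8-fold higher number from compound 1 to compound 2 (0.45 log units; beyond the scatter), where dimethylamino stands in place of pyrrolidin-1-yl on a saturated ring carbon.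

The unmeasured compound 3 `CN1CCN(CCC(=O)N2CCC3(N4CCCC4)CC(c4ccccc4)C2C(c2ccccc2)C3)CC1` differs from compound 1 in (4-methylpiperazin-1-yl)methyl in place of 4-methylpiperazin-1-yl on a saturated chain carbon bound to a carbonyl carbon. For the measured compounds named here, the single measured step concerns a different part of the shared core, so no measured step bears on this change; the data give no guidance on it. With nothing to point in either direction, the step to compound 3 is expected to stay within the scatter, so that compound 3 is estimated at 70000 nM with a range from 30000 nM to 160000 nM. The step this expectation means is a 1.0-fold higher number from compound 1 to compound 3 (0.01 log units; within the scatter).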

Compound 3, half-maximal inhibitory concentration: 75400 nM
For compound 3 the middle estimate is 1.1-fold (0.03 log units) below the measured one, within the range that was stated.
By their numbers in this assay, from the lowest: compounds 1 and 3 (each within the scatter of the next); then compound 2.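

In this assay, the longer link at this position gives a 1.1-fold higher number from compound 1 to compound 3 (0.04 log units; within the scatter) and so puts compound 1 and compound 3 within the scatter of each other. Among the compounds shown here, this is the first reading of (4-methylpiperazin-1-yl)methyl in place of 4-methylpiperazin-1-yl on a saturated chain carbon bound to a carbonyl carbon, and it contrasts with the earlier step on a saturated ring carbon, which lay beyond the scatter. Nothing measured here accounts for this result.

The compounds shown leave open how a longer chain, such as 3-(4-methylpiperazin-1-yl)propyl, or a morpholin-4-yl group in place of the 4-methylpiperazin-1-yl group would read in this assay. They also leave open whether the 2-(4-methylpiperazin-1-yl)ethyl chain would read the same alongside the dimethylamino group of compound 2.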